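The source may report more compounds than this note shows. Statements on the series, on what has been measured and on what is new or still open speak of the compounds shown alone.

In a functional assay on LS174T cells (Homo sapiens) for inhibition, with a stated time of 4 days, tested at 1 uM (a higher number here means a stronger effect of the compound at the concentration tested, a lower number a weaker effect), two compounds that share one core have been measured. Compound 1, `Fc1cccc(F)c1C#Cc1ccc2c(Cl)ccnc2c1`, gives 23.1% in this assay, and compound 2, `Nc1ccnc2cc(C#Cc3c(F)cccc3F)ccc12`, gives 23.6%. For the measured compounds named here, the only step between them, a number 0.5 percentage points higher from compound 1 to compound 2 (within the scatter), lies within the scatter. Compound 2 thus holds the higher of the two numbers, with compound 1 nearest, but the gap between them carries no weight.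

Compound 3, `Fc1cccc(F)c1C#Cc1ccc2cccnc2c1`, has not yet been measured. Its change from compound 2 is hydrogen in place of amino on an aromatic carbon. Going by the values given here, the one measured step that bears on this change is the exchange at the same place on the core, and that step, a number 0.5 percentage points higher from compound 1 to compound 2 (within the scatter), stayed within the scatter. Because a number 0.5 percentage points higher from compound 1 to compound 2 (within the scatter) was that small, no step beyond the scatter is expected here either, and the expected step is a number 3.6 percentage points lower from compound 2 to compound 3 (within the scatter). Compound 3 is therefore estimated to give 20% in this assay, with a range from 5% to 35%.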

Compound 3, a percentage reported as inhibition, at one concentration (the size of the read-out at that concentration, not a potency): 90.7%
Estimate against measurement, compound 3: 70.7 percentage points below; measured number above the stated range.
By their numbers in this assay, from the lowest: compounds 1 and 2 (each within the scatter of the next); then compound 3.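

In this assay, hydrogen on the aromatic carbon opposite the ring nitrogen gives a number 67.1 percentage points higher from compound 2 to compound 3 (beyond the scatter), and against the chloro group it gives a number 67.6 percentage points higher from compound 1 to compound 3 (beyond the scatter). The earlier pair showed only that amino and chloro at this carbon could not be told apart; the new steps show that the carbon is far from indifferent, with the large difference lying between hydrogen and either of these groups. Nothing at hand explains this difference.

The compounds shown leave open whether a fluoro, methyl or methoxy group on this carbon would give a number close to that of compound 3 or close to those of compounds 1 and 2. They also leave open whether the effect of hydrogen here would persist with a change elsewhere on the shared core.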